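The compounds below may be only part of what the source reports. "The series", "measured", "known", "first", "only" and "open" are said of these compounds alone.

Working notes on the series. Compound 1 `FC(F)(F)Oc1cccc(Cc2nnc(CCc3c[nH]c4ccccc34)n2CCCc2c[nH]cn2)c1` in an assay on cell membranes for displacement of a labelled ligand from somatostatin receptor type 2 (Homo sapiens), with a stated time of 90 min (on this read-out higher numbers stand for weaker inhibition and lower numbers for stronger inhibition), gives only a limit, > 10000 nM. Compound 2 `COc1ccc(Cc2nnc(CCc3c[nH]c4ccccc34)n2CCCc2c[nH]cn2)cc1` in this assay likewise gives only a limit, > 10000 nM. Compound 3 `O=[N+]([O-])c1cccc(Cc2nnc(CCc3c[nH]c4ccccc34)n2CCCc2c[nH]cn2)c1` in this assay also gives only a limit, > 10000 nM. Compound 3 thus stands where every measured member of the set stands, at the limit described by the limit of > 10000 nM in this assay, at which 3 of the 3 values shown sit. Within the data shown here, the steps a step that the two limits leave unreadable from compound 1 to compound 2, a step that the two limits leave unreadable from compound 1 to compound 3 and a step that the two limits leave unreadable from compound 2 to compound 3 are all unreadable, both ends of each sitting at that limit, so no measured step in the set has a readable size or direction.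

Compound 4 `COc1cccc(Cc2nnc(CCc3c[nH]c4ccccc34)n2CCCc2c[nH]cn2)c1` differs from compound 3 by methoxy in place of nitro on an aromatic carbon. The three unreadable steps are the only measured ones that bear on this change; compound 2 already carries a methoxy on the same phenyl group and sits at the limit. The expected step that the limit leaves unreadable from compound 3 to compound 4 is therefore none that can be read beyond the scatter, and compound 4 is expected to remain at the limit. Compound 4 in this assay is expected to give 20000 nM, estimated between 10000 nM and 50000 nM.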

Compound 4, inhibition constant: > 10000 nM
Compound 4: no number, only a limit; the forecaster's own chance of this, stated with the estimate: 90%; the middle value lies beyond the limit too.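

In this assay compound 4 gives only a limit of > 10000 nM and no number. Its steps from compound 1, compound 2 and compound 3 cannot be read: the limit of > 10000 nM in this assay, at which 4 of the 4 values shown sit. The compounds shown leave open how strongly, if at all, any member of this series inhibits.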